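The compounds below may be only part of what the source reports. "The series", "measured", "known", "first", "only" and "open" are said of these compounds alone.

Measured in a physicochemical assay for solubility, at pH 7.4; on this read-out lower numbers stand for lower solubility and higher numbers for higher solubility:
- Compound 1 `Cn1cc(C(=O)Nc2ccc(-c3ccccc3)c(C(F)(F)F)c2)c(=O)c2ccccc21`: 1.3 ug/mL
- Compound 2 `Cn1cc(C(=O)Nc2ccc(-c3ccccn3)c(C(F)(F)F)c2)c(=O)c2cnccc21`: 120 ug/mL
- Compound 3 `Cn1cc(C(=O)Nc2ccc(-c3ccccc3)c(C(F)(F)F)c2)c(=O)c2cccnc21`: < 1 ug/mL, a limit of the assay

Compound 2 stands highest of the two numbers at 120 ug/mL, and compound 1 comes next at 1.3 ug/mL. The gap between these two numbers lies beyond the scatter. Compound 4 `Cn1cc(C(=O)Nc2ccc(-c3ccccc3)c(C(F)(F)F)c2)c(=O)c2cnccc21` keeps the core of compound 2 but has phenyl in place of pyridin-2-yl on an aromatic carbon, ortho to a trifluoromethyl group (phenyl in place of pyridin-2-yl on an aromatic carbon). For the measured compounds named here, no measured pair isolates this change. Compound 1 also carries phenyl and gives 1.3 ug/mL, but its core differs from that of compound 2, so the size of any fall stays uncertain. A fall beyond the scatter in this assay is expected for the step of a 15-fold lower number from compound 2 to compound 4 (1.18 log units; beyond the scatter). Compound 4 is estimated at 8 ug/mL, with an expected range of 1.5 ug/mL to 40 ug/mL.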

Compound 4, solubility: < 1 ug/mL
Compound 4: a limit, no number; the forecaster's own chance of this, stated with the estimate: 10%; middle value at least 8.0-fold (0.90 log units) from the limit.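

In this assay, phenyl in place of pyridin-2-yl on an aromatic carbon, ortho to a trifluoromethyl group, gives an at least 120-fold lower number from compound 2 to compound 4 (2.07 log units; beyond the scatter). With the core held fixed, this step rests on that one change alone. The value of compound 4 is a limit, so the step sets only a minimum size: the limit of < 1 ug/mL in this assay, at which 2 of the 4 values shown sit.

On these data alone, whether pyridin-2-yl gives a similar step on the cores of compound 1 and compound 3 stays open, as neither has a pyridin-2-yl partner here. Also open, as far as these compounds go, is how a morpholine or a primary amine at this position would compare with pyridin-2-yl.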